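A few compounds are considered here, and "the series" means these few. Any claim that something is new, unique, unknown or untested is made for them only; others in the source may bear on it.

Going by the values given here, in a functional assay for inhibition, with Homo sapiens as the target (on this read-out higher numbers stand for weaker inhibition and lower numbers for stronger inhibition), compound 1 (`CCC1CS(=O)(=O)c2cc(C(=O)N=C(N)N)c(C)cc21`) gives 78 nM and compound 2 (`Cc1cc2c(cc1C(=O)N=C(N)N)S(=O)(=O)CC2N`) gives 692 nM as the higher of the two numbers so far. Compound 3 (`Cc1cc2c(cc1C(=O)N=C(N)N)S(=O)(=O)CC2`) follows from compound 2 through hydrogen in place of amino on a saturated ring carbon with hydrogen in place of amino on a saturated ring carbon. Among the compounds with values here, one measured step bears on this change: an 8.9-fold higher number from compound 1 to compound 2 (0.95 log units; beyond the scatter) came with amino in place of ethyl on a saturated ring carbon and lies beyond the scatter. Within the data shown here, no compound with hydrogen at that carbon has a number yet, so this step suggests a direction more than a size. A lower number than the 692 nM of compound 2 is therefore expected, by a somewhat smaller margin than that step. The estimated change is a 3.5-fold lower number from compound 2 to compound 3 (0.54 log units; beyond the scatter) on this reasoning. For compound 3 the expected value is 200 nM with an estimated range from 70 nM to 600 nM across repeat measurements.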

Compound 3, half-maximal inhibitory concentration: 587 nM
The estimate for compound 3 lay 2.9-fold (0.47 log units) below the measured number; measured number inside the range.
By their numbers in this assay, from the lowest: compound 1; then compounds 3 and 2 (each within the scatter of the next).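

In this assay, replacing the amino group on the saturated ring carbon with hydrogen makes no difference that can be told from the scatter, with a 1.2-fold lower number from compound 2 to compound 3 (0.07 log units; within the scatter) as the step, so amino and hydrogen cannot be told apart at this position. Ethyl is the group that stands apart here, with a 7.5-fold higher number from compound 1 to compound 3 (0.88 log units; beyond the scatter) on replacing it with hydrogen, so the earlier step from ethyl to amino reads as the loss of ethyl rather than as a penalty from amino. No measured evidence here accounts for this effect of ethyl.

The compounds shown leave open whether a methyl group or a longer chain such as propyl at this carbon would give a number near that of ethyl. They also leave open how a hydroxyl group or a carboxylic acid would behave there.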